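Swapping methoxy for cyano on a potent series

A few compounds are considered here, and "the series" means these few. Any claim that something is new, unique, unknown or untested is made for them only; others in the source may bear on it.

- compound 1 `CCSC[C@@](O)([C@@H](Nc1cccc2nc(C)ccc12)c1cccc(F)c1OC)C(F)(F)F`: 2 nM
- compound 2 `COc1ccc([C@H](Nc2cccc3nc(C)ccc23)[C@](O)(CSC)C(F)(F)F)c(Cl)c1F`: 0.126 nM
- compound 3 `COC[C@@](O)([C@@H](Nc1cccc2nc(C)ccc12)c1ccc(OC)c(F)c1Cl)C(F)(F)F`: 0.2 nM
- compound 4 `COc1ccc([C@H](Nc2cccc3nc(C)ccc23)[C@](O)(CC#N)C(F)(F)F)c(Cl)c1F`: not yet measured

In a functional assay on THP-1 cells (Homo sapiens) (a higher number here means a weaker inhibitor, a lower number a stronger inhibitor), compound 3 gives 0.2 nM, within the scatter of compound 2 and far below compound 1. Compound 4 has cyano in place of methoxy on a saturated chain carbon, two bonds along the chain from an oxygen on a saturated carbon. Within the data shown here, only one measured step changes this same spot: methoxy in place of methylsulfanyl, a 1.6-fold higher number from compound 2 to compound 3 (0.20 log units; within the scatter). No cyano group has been measured here, so this is thin evidence. A change beyond the scatter is not expected, and the estimated change is a 1.5-fold higher number from compound 3 to compound 4 (0.18 log units; within the scatter). Compound 4 is estimated at 0.3 nM, with a range of 0.08 nM to 1.5 nM.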

Compound 4, half-maximal inhibitory concentration: 1.26 nM
For compound 4 the middle estimate is 4.2-fold (0.62 log units) below the measured one, within the range that was stated.
By their numbers in this assay, from the lowest: compounds 2 and 3 (each within the scatter of the next); then compounds 4 and 1 (each within the scatter of the next).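

In this assay, methoxy and methylsulfanyl could not be told apart at this spot, but cyano can: it brings a 6.3-fold higher number from compound 3 to compound 4 (0.80 log units; beyond the scatter) and a 10-fold higher number from compound 2 to compound 4 (1.00 log units; beyond the scatter) on the same core. Methoxy and cyano match in heavy atoms and hydrogen-bond acceptors, so those counts alone do not settle the number here. Nothing measured here explains the loss.

Still open, on these data alone, is whether an amine, an ethoxy group or a longer chain on this carbon would stay with compound 2 and compound 3 or move towards compound 4.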